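A Second Bromine on the Hydroxyphenyl Hydrazone

The source may report more compounds than this note shows. Statements on the series, on what has been measured and on what is new or still open speak of the compounds shown alone.

Three compounds built on the core of compound 1 `O=C(N/N=C/c1ccccc1)Nc1ccc(Oc2ccnc3[nH]ccc23)c(F)c1` have been tested in a functional assay on A549 cells (Homo sapiens) for antiproliferative activity, read by MTT assay, with a stated time of 72 h; a higher number here means a weaker inhibitor, a lower number a stronger inhibitor. In this assay compound 1 gives 2500 nM. Compound 2 `O=C(N/N=C/c1cccc(Br)c1)Nc1ccc(Oc2ccnc3[nH]ccc23)c(F)c1` differs from compound 1 by bromo in place of hydrogen on an aromatic carbon; in this assay compound 2 gives 2220 nM, and the step is a 1.1-fold lower number from compound 1 to compound 2 (0.05 log units; within the scatter). Compound 3 `O=C(N/N=C/c1ccc(O)c(Br)c1)Nc1ccc(Oc2ccnc3[nH]ccc23)c(F)c1` differs from compound 1 by 3-bromo-4-hydroxyphenyl in place of phenyl on a carbon with a double bond to nitrogen; in this assay compound 3 gives 9250 nM. The step from compound 1 is a 3.7-fold higher number from compound 1 to compound 3 (0.57 log units; beyond the scatter), and that from compound 2 is a 4.2-fold higher number from compound 2 to compound 3 (0.62 log units; beyond the scatter), so compound 3 stands at the highest number of the three.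

Compound 4 `O=C(N/N=C/c1cc(Br)c(O)c(Br)c1)Nc1ccc(Oc2ccnc3[nH]ccc23)c(F)c1` is not yet measured. It differs from compound 3 by bromo in place of hydrogen on an aromatic carbon. Within the data shown here, this is the same kind of change as the one made from compound 1 to compound 2, which gave the step of a 1.1-fold lower number from compound 1 to compound 2 (0.05 log units; within the scatter). The surroundings are not the same, however: in compound 4 the entering bromo sits ortho to a hydroxy group and meta to a bromo group, while in compound 2 it sits only meta to a large group. The step from compound 3 to compound 4 in this assay is expected to be a 1.2-fold lower number from compound 3 to compound 4 (0.09 log units; within the scatter), resting on the step of a 1.1-fold lower number from compound 1 to compound 2 (0.05 log units; within the scatter) having stayed within the scatter. Compound 4 is accordingly estimated at 7500 nM in this assay, with a range from 3000 nM to 19000 nM.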

Compound 4, half-maximal inhibitory concentration: 16200 nM
For compound 4 the middle estimate is 2.2-fold (0.33 log units) below the measured one; low and high end bracket the measured number.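

In this assay, adding the second bromo gives a 1.8-fold higher number from compound 3 to compound 4 (0.24 log units; within the scatter), whereas the wider replacements of the aryl group give a 6.5-fold higher number from compound 1 to compound 4 (0.81 log units; beyond the scatter) and a 7.3-fold higher number from compound 2 to compound 4 (0.86 log units; beyond the scatter), so compound 4 stands clearly apart from compound 1 and compound 2 but not from compound 3. Set side by side, the two bromo steps show that the change carried from one core to the other without a difference that can be told from the scatter: the same change on two cores in this assay, a 1.1-fold lower number (0.05 log units; within the scatter) from compound 1 to compound 2 and a 1.8-fold higher number (0.24 log units; within the scatter) from compound 3 to compound 4, 2.0-fold (0.29 log units) apart, within the scatter of two such steps This agreement rests on only two pairs, so it does not show that the change would behave alike on other cores in the series, and it does not explain why compound 3 and compound 4 give higher numbers than compound 1 and compound 2.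

The compounds shown leave open whether chloro or methyl in place of the entering bromo would give a step of similar size on these two cores. They also leave open how the 3,5-dibromo-4-hydroxyphenyl compound would read with methoxy in place of its hydroxy group, or with an amine or a carboxylic acid on the same ring.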